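The source may report more compounds than this note shows. Statements on the series, on what has been measured and on what is new or still open speak of the compounds shown alone.

Measured so far:
compound 1 `CCNc1nc2ccsc2c(=O)n1CC` — 2900 nM
compound 2 `CCn1c(NC(C)C)nc2c(C3CCN(c4ccccn4)CC3)csc2c1=O` — 6.8 nM
compound 3 `CCn1c(NC(C)C)nc2c(C3CCNCC3)csc2c1=O` — 190 nM

Working notes. In an assay on cells for inhibition of high affinity 3',5'-cyclic-AMP phosphodiesterase 7A (Homo sapiens), read by scintillation counting and cAMP accumulation, with a stated time of 30 min (a higher number here means a weaker inhibitor, a lower number a stronger inhibitor), compound 1 gives the highest number of the three; compound 3 sits a good way below it and compound 2 further still, both gaps beyond the scatter. Among the measured compounds shown here, the one step that joins two measured compounds, a 28-fold higher number from compound 2 to compound 3 (1.45 log units; beyond the scatter), concerns a different part of the series: it changes the substituent on the amine nitrogen in the ring, a position that compound 1 does not carry.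

Compound 4 `CCCNc1nc2ccsc2c(=O)n1CC` differs from compound 1 by methyl in place of hydrogen on a saturated chain carbon, two bonds along the chain from a nitrogen on an aromatic ring. For the measured compounds named here, no measured pair shows this change, so nothing here tells its direction or size; the large step from compound 2 to compound 3 is of a different kind and cannot be carried over. The expectation for compound 4 in this assay is therefore a step of a 1.2-fold lower number from compound 1 to compound 4 (0.06 log units; within the scatter), which is taken as no change beyond the scatter.

Compound 4 is accordingly estimated at 2500 nM, with a range of 900 nM to 7000 nM.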

Compound 4, half-maximal inhibitory concentration: 1400 nM
Compound 4: middle estimate off by 1.8-fold (0.25 log units), on the high side, within the range that was stated.
By their numbers in this assay, from the lowest: compound 2; then compound 3; then compound 4; then compound 1.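

In this assay, among the compounds shown here, the change from ethylamino to propylamino gives a 2.1-fold lower number from compound 1 to compound 4 (0.32 log units; beyond the scatter), the first reading of what a methyl in place of hydrogen does at this chain carbon. The step is modest yet beyond the scatter, so on the core of compound 1 this position accepts the added methyl and the number moves down rather than up. No evidence at hand bears on what lies behind this step.

On these data alone, a single step fixes the direction for one chain length only, so it remains open whether a longer chain such as butylamino would continue the fall or reverse it. Also open, as far as these compounds go, is how a hydroxyl or an amine at the end of the chain would read, and whether the same change would give a similar step on compound 2 .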